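Sulfonyl aryl halogen swap on an inactive sulfonamide

The source may report more compounds than this note shows. Statements on the series, on what has been measured and on what is new or still open speak of the compounds shown alone.

Compound 1 `CCN(CC)C(=O)CN(c1ccc(C)cc1)S(=O)(=O)c1cccc(Cl)c1` was tested in a functional assay on CHO cells for inhibition of Orexin/Hypocretin receptor type 1 (Homo sapiens), read by FLIPR and calcium flux; a lower number here means a stronger inhibitor, a higher number a weaker inhibitor. In this assay compound 1 gives > 10000 nM, which is a limit of the assay and not a number, so compound 1 stands at the limit of > 10000 nM in this assay, at which 1 of the 2 values shown sits. Compound 2 `CCN(C(=O)CN(c1cc(N(C)C)ccc1Cl)S(=O)(=O)c1ccc(OC)c(OC)c1)c1cccc(C)n1` gives 17 nM in this assay. Compound 3 `CCN(CC)C(=O)CN(c1ccc(C)cc1)S(=O)(=O)c1ccccc1F` differs from compound 1 by 2-fluorophenyl in place of 3-chlorophenyl on a sulfonyl sulfur. With compound 1 only a limit, the expected step is a step that the limit leaves unreadable from compound 1 to compound 3, none beyond the scatter. For compound 3 the estimate in this assay is 20000 nM, ranging from 5000 nM to 80000 nM.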

Compound 3, half-maximal inhibitory concentration: > 10000 nM
Compound 3 ended at the assay's limit (the forecaster's own chance of this, stated with the estimate: 75%); the middle value does not contradict the limit.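

In this assay compound 1 and compound 3 both sit at a limit of the assay and not at a number, so no step can be read between them. Left open is which structural differences matter for compound 2, which gives 17 nM.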